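Thiophene to Fluorophenyl at a Solubility Ceiling

The source may report more compounds than this note shows. Statements on the series, on what has been measured and on what is new or still open speak of the compounds shown alone.

Three close relatives of one shared core have been measured in a physicochemical assay for solubility, at pH 7; on this read-out lower numbers stand for lower solubility and higher numbers for higher solubility. Compound 1 `CC1(C)c2[nH]nc(NC(=O)c3ccc(F)cc3)c2CN1C(=O)C1CCN(C2CC2)CC1` reaches the upper limit of this assay, recorded as > 225000 nM. Compound 2 `CN1CCC(C(=O)N2Cc3c(NC(=O)c4ccsc4)n[nH]c3C2(C)C)CC1` also reaches the upper limit of this assay, recorded as > 225000 nM. Compound 3 `CC(=O)N1CCC(C(=O)N2Cc3c(NC(=O)c4ccc(F)cc4)n[nH]c3C2(C)C)CC1` gives an actual number in this assay, 204000 nM. Within the data shown here, the only measured step, an at least 1.1-fold lower number from compound 1 to compound 3 (0.04 log units; that floor lies within the scatter), lies within the scatter, so it tells of no real change. Compound 2 thus stands at the ceiling of this assay, a ceiling shared by most of the values shown (the limit of > 225000 nM in this assay, at which 2 of the 3 values shown sit).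

Compound 4 `CN1CCC(C(=O)N2Cc3c(NC(=O)c4cccc(F)c4)n[nH]c3C2(C)C)CC1` differs from compound 2 in one place: 3-fluorophenyl in place of thiophen-3-yl on a carbonyl carbon. Among the measured compounds shown here, no measured pair shows this exchange, so no step bears on it directly; what can be said is that compound 1 and compound 3, whose structures stand above, sit at or close to the same ceiling. The expected step is an at least 1.0-fold lower number from compound 2 to compound 4 (0.00 log units; that floor lies within the scatter), no real change in this assay. Compound 4 is estimated at 220000 nM, between 110000 nM and 225000 nM, and will most likely be reported again only as a limit.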

Compound 4, solubility: > 225000 nM
Compound 4 ended at the assay's limit; the forecaster's own chance of this, stated with the estimate: 60%; middle value at least 1.0-fold (0.00 log units) away from the limit.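

Compound 2 and compound 4 both stop at a limit of this assay rather than at a number, so the step between them cannot be read: the limit of > 225000 nM in this assay, at which 3 of the 4 values shown sit.

The compounds shown leave open whether 3-fluorophenyl in place of thiophen-3-yl on a carbonyl carbon changes the read-out at all.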